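The source may hold more compounds than are shown below. What is called first, only, known or untested is meant among the compounds shown, and "the series" means these compounds.

Measured compounds:
- Compound 1, `Cc1ccc(NC(=S)NC(=O)c2ccc(OCc3ccccc3)cc2)cc1-c1nc2ccccc2[nH]1`: 67100 nM
- Compound 2, `Cc1ccc(NC(=S)NC(=O)c2ccc(OCc3ccccc3Cl)cc2)cc1-c1nc2ccccc2[nH]1`: 57100 nM

In a functional assay on SW-620 cells (Homo sapiens) for inhibition, read by MTT assay, with a stated time of 48 h (on this read-out higher numbers stand for weaker inhibition and lower numbers for stronger inhibition), compound 1 gives 67100 nM and compound 2 gives 57100 nM. Going by the values given here, compound 2 holds the lower of the two numbers, but the only recorded step, a 1.2-fold lower number from compound 1 to compound 2 (0.07 log units; within the scatter), lies within the scatter, so the two compounds cannot be told apart on this read-out. Compound 3, `Cc1ccc(NC(=S)NC(=O)c2ccc(OCc3ccc(Cl)c(Cl)c3)cc2)cc1-c1nc2ccccc2[nH]1`, has not yet been measured. It differs from compound 2 by 3,4-dichlorophenyl in place of 2-chlorophenyl on a saturated chain carbon bound to an oxygen on an aromatic ring. Among the compounds with values here, the one measured step that bears on this change is a 1.2-fold lower number from compound 1 to compound 2 (0.07 log units; within the scatter), in which a single chlorine entering the benzyl group produced no shift beyond the scatter. Compound 3 carries a second chlorine within that same group, and with nothing beyond a within-scatter step to build on, no step beyond the scatter is expected in this assay, with at most a slight drift toward a lower number. Compound 3 is therefore expected to give about 48000 nM in this assay, with a range from 20000 nM to 115000 nM. For compound 3 this estimate means an expected step of a 1.2-fold lower number from compound 2 to compound 3 (0.08 log units; within the scatter).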

Compound 3, half-maximal inhibitory concentration: 30700 nM
The estimate for compound 3 lay 1.6-fold (0.19 log units) above the measured number; low and high end bracket the measured number.
By their numbers in this assay, from the lowest: compounds 3, 2 and 1 (each within the scatter of the next, the first and the last beyond it).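

Going by these compounds alone, compound 3 gives the first step beyond the scatter at this place, the saturated chain carbon bound to an oxygen on an aromatic ring: 3,4-dichlorophenyl in place of phenyl gives a 2.2-fold lower number from compound 1 to compound 3 (0.34 log units; beyond the scatter) in this assay, a modest step that the single chlorine of compound 2 did not produce. Replacing 2-chlorophenyl with 3,4-dichlorophenyl gives a 1.9-fold lower number from compound 2 to compound 3 (0.27 log units; within the scatter), which stays within the scatter, so compound 2 and compound 3 cannot be told apart and the dichlorinated group stands apart only from the plain phenyl of compound 1. No measurement is available that would account for this step.

Going by these compounds, compound 2 and compound 3 differ both in how many chlorines they carry and in where those chlorines stand on the ring, so it remains open which of the two matters for the step from the plain phenyl. Also open, on these data alone, is how a methoxy group or an amine on this phenyl ring, or a longer chain at the saturated carbon, would read in this assay.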